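The source may hold more compounds than are shown below. What is called first, only, known or untested is meant among the compounds shown, and "the series" means these compounds.

Measured compounds:
Compound 1 `Oc1ccc(-c2cc(-c3ccc(Cl)cc3)nc(-c3cccnc3)c2)cc1` — in a functional assay on HCT-15 cells (Homo sapiens) for cytotoxicity, read by CCK-8 assay and cell counting, with a stated time of 2 days (on this read-out higher numbers stand for weaker inhibition and lower numbers for stronger inhibition), compound 1 gives 20700 nM.
Compound 2 `Oc1cccc(-c2cc(-c3cccnc3)nc(-c3ccccc3Cl)c2)c1` — in this assay compound 2 has "not determined" (no result reported).
Compound 3 `Oc1cccc(-c2cc(-c3ccc(Cl)cc3)nc(-c3cccnc3)c2)c1` — in this assay compound 3 gives 16800 nM.

Compound 3 holds the lowest of the two numbers, but its nearest neighbour is compound 1, and the step of a 1.2-fold lower number from compound 1 to compound 3 (0.09 log units; within the scatter) lies within the scatter, so the two cannot be placed in order. Compound 4 `Oc1cccc(-c2cc(-c3ccc(Cl)cc3)nc(-c3ccccn3)c2)c1` has not been measured in this assay. The change from compound 3 to compound 4 is pyridin-2-yl in place of pyridin-3-yl on an aromatic carbon. Within the data shown here, the only measured step, from compound 1 to compound 3, concerns the hydroxyphenyl group and not the pyridyl group, so no measured step bears on this change, and the data give no ground for expecting a shift beyond the scatter in either direction. Compound 4 is therefore expected to sit close to compound 3, with the step of a 1.0-fold higher number from compound 3 to compound 4 (0.01 log units; within the scatter) expected to stay within the scatter. The estimate for compound 4 is 17000 nM, with a range from 6000 nM to 50000 nM.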

Compound 4, half-maximal inhibitory concentration: 13500 nM
Estimate against measurement, compound 4: 1.3-fold (0.10 log units) above, within the range that was stated.
By their numbers in this assay, from the lowest: compounds 4, 3 and 1 (each within the scatter of the next).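

Among these compounds, compound 4 gives the first reading of a change in the pyridyl group itself, on the aromatic carbon next to the ring nitrogen of the shared core, whereas the earlier step concerned only the hydroxyphenyl group. In this assay, the step of a 1.2-fold lower number from compound 3 to compound 4 (0.09 log units; within the scatter) shows that exchanging pyridin-3-yl for pyridin-2-yl at this place, with the same atoms joined differently, leaves the number within the scatter. No measured evidence is available here that would explain this result. The compounds shown leave open whether pyridin-4-yl, an amine such as piperidine or a carboxylic acid at this place would move the number beyond the scatter. On these data alone, compounds 1, 3 and 4 also share the 4-chlorophenyl group, so the effect of replacing it, for instance with a 4-aminophenyl group, remains open too.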